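Swapping the oxazole for a methyltriazole in the shared core

The source may hold more compounds than are shown below. What is called first, only, known or untested is meant among the compounds shown, and "the series" means these compounds.

Of the compounds shown here, three sharing one core have been measured in a functional assay on HEK293 cells for agonist activity at Free fatty acid receptor 1 (Homo sapiens), read by fluorescence and calcium flux, with a stated time of 10 min; on this read-out higher numbers stand for larger maximal responses and lower numbers for smaller maximal responses. Compound 1, `O=C(O)CCc1ccc(OCC2COc3ccc(Br)cc3O2)cc1F`, gives 81% in this assay. Compound 2, `CCOC(CC(=O)O)c1ccc(OCC2COc3ccc(Cl)cc3O2)cc1`, gives 46%. Compound 3, `O=C(O)CC(c1ccc(OCC2COc3ccc(Cl)cc3O2)cc1)c1cnco1`, gives 63%, the second highest of the three numbers: it lies beyond the scatter above compound 2 and beyond the scatter below compound 1. Among the compounds with values here, the one step between neighbours, a number 17 percentage points higher from compound 2 to compound 3 (beyond the scatter), places a five-membered aromatic ring where an ethoxy group had stood on the saturated chain carbon bound to an aromatic carbon and a saturated chain carbon.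

Compound 4, `Cn1nncc1C(CC(=O)O)c1ccc(OCC2COc3ccc(Cl)cc3O2)cc1`, is not yet measured. It differs from compound 3 in this way: 1-methyl-1H-1,2,3-triazol-5-yl in place of 1,3-oxazol-5-yl on a saturated chain carbon bound to an aromatic carbon and a saturated chain carbon. Within the data shown here, no measured step exchanges one five-membered aromatic ring for another at this position; the only step at this position, from an ethoxy group to an oxazole, was modest. The expected change is therefore small, within or close to the scatter, with no firm direction. Compound 4 is expected to give about 62%, between 42% and 80%, a step of a number 1 percentage points lower from compound 3 to compound 4 (within the scatter) that is estimated, not measured.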

Compound 4, largest response reached (Emax), in percent of the reference or control that the assay uses: 70%
Beside the measured number, compound 4's estimate is 8 percentage points below it, and the stated range covers the measured number.
By their numbers in this assay, from the lowest: compound 2; then compounds 3 and 4 (each within the scatter of the next); then compound 1.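

In this assay, the exchange of one five-membered aromatic ring for another on this saturated chain carbon gives a number 7 percentage points higher from compound 3 to compound 4 (within the scatter), so 1-methyl-1H-1,2,3-triazol-5-yl and 1,3-oxazol-5-yl cannot be told apart on this read-out, although they differ in their hetero atoms and the entering ring carries a methyl group. Measured against ethoxy at the same place, the triazole gives a number 24 percentage points higher from compound 2 to compound 4 (beyond the scatter), so the gain over ethoxy is no longer tied to the oxazole alone: among compounds 2, 3 and 4, both five-membered aromatic rings stand clear of ethoxy, and no compound shown goes against this. Nothing available bears on what lies behind this result.

The compounds shown leave open whether a six-membered aromatic ring such as phenyl or pyridyl, or a primary amine, on this saturated chain carbon would give a response in the same range. They also do not tell whether a 1,2,3-triazole without its methyl group would match compound 4 or fall back towards compound 2.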